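Swapping the acyl group on compound 2

This account rests on a few compounds, and the source may have more. Where it says the series, first, only, none or still open, it means among the compounds named here.

Values measured in a functional assay on A2780 cells (Homo sapiens) for cytotoxicity, read by MTT assay, with a stated time of 72 h (on this read-out higher numbers stand for weaker inhibition and lower numbers for stronger inhibition), so far:
compound 1 `CN(C)c1ccc(C(=O)N(CCCCCC(=O)Nc2cc(F)ccc2N)CC(=O)NCc2ccccc2)cc1` gives 25900 nM
compound 2 `Cc1cc(C)cc(C(=O)N(CCCCCC(=O)Nc2ccccc2N)CC(=O)NCc2ccccc2)c1` gives 20900 nM

In this assay compound 2 gives 20900 nM as its value, and compound 1 gives 25900 nM as its value. These two numbers lie within the scatter of each other, so the data do not separate the two compounds.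

Still unmeasured is compound 3 `CN(C)c1ccc(C(=O)N(CCCCCC(=O)Nc2ccccc2N)CC(=O)NCc2ccccc2)cc1` in this series. It departs from compound 2 by one change, 4-(dimethylamino)phenyl in place of 3,5-dimethylphenyl on a carbonyl carbon in full, which places 4-(dimethylamino)phenyl in place of 3,5-dimethylphenyl on a carbonyl carbon. Within the data shown here, no measured pair isolates this change. The nearest evidence is compound 1, which carries the same 4-(dimethylamino)phenyl on a carbonyl carbon but differs elsewhere, and which gives 25900 nM as its value, within the scatter of compound 2. No step beyond the scatter is therefore expected in this assay here.

The expected size of the change is a 1.1-fold higher number from compound 2 to compound 3 (0.02 log units; within the scatter) on this estimate. Compound 3 is estimated at 22000 nM with an expected range from 10000 nM to 45000 nM in this assay.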

Compound 3, half-maximal inhibitory concentration: 18500 nM
Estimate against measurement, compound 3: 1.2-fold (0.08 log units) above; the measured number falls inside the stated range.
By their numbers in this assay, from the lowest: compounds 3, 2 and 1 (each within the scatter of the next).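

In this assay the change on the carbonyl carbon can now be read as a single step: 4-(dimethylamino)phenyl in place of 3,5-dimethylphenyl gives a 1.1-fold lower number from compound 2 to compound 3 (0.05 log units; within the scatter) and so does not separate the two groups at this position. Compound 1 and compound 2 differ in more than one place and could not show this, but compound 3 now supplies a matched partner for each of them. The second pair isolates the aromatic carbon, where hydrogen in place of fluoro gives a 1.4-fold lower number from compound 1 to compound 3 (0.15 log units; within the scatter) and likewise leaves the two compounds unseparated, so neither single change in this small set moves the read-out beyond the scatter. No measurement here offers an explanation for how closely these compounds read.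

As far as these compounds go, whether a cyclohexyl or pyridyl group on the carbonyl carbon would give a step beyond the scatter remains open. The same question stands for a chloro or methoxy group on the aromatic carbon that carries fluoro in compound 1, and for a longer chain in the shared core.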